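The source may report more compounds than this note shows. Statements on the series, on what has been measured and on what is new or still open speak of the compounds shown alone.

Measured compounds:
compound 1 `CCc1nc(-c2cccc(F)c2)c(C(=O)N2CCN(c3cccc(OC)c3)CC2)o1` — 201 nM
compound 2 `COc1ccc(-c2nc(C)oc2C(=O)N2CCN(c3cccc(Cl)c3)CC2)cc1` — "not active" (no number reported)
compound 3 `COc1cc(OC)cc(N2CCN(C(=O)c3onc(C)c3-c3ccccc3)CC2)c1` — 152 nM

In a functional assay on HL-60 cells (Homo sapiens) for inhibition, read by MTT assay, with a stated time of 72 h (on this read-out higher numbers stand for weaker inhibition and lower numbers for stronger inhibition), compound 1 gives 201 nM, and compound 3 gives 152 nM; these two values lie within the scatter of each other. Compound 2 stands apart: in this assay compound 2 was recorded as "not active" (no number reported), with no number reported, so it cannot be placed on the scale of the other two.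

Compound 4 `Cc1nc(-c2ccccc2F)c(C(=O)N2CCN(c3cccc(Cl)c3)CC2)o1` is not yet measured. It differs from compound 2 in one place: 2-fluorophenyl in place of 4-methoxyphenyl on an aromatic carbon. The core and the piperazine-linked chlorophenyl group are retained.

Compound 2 gave "not active" (no number reported), with no number reported. The other measured compounds, compound 1 at 201 nM and compound 3 at 152 nM, do give numbers. The direction of this step is therefore uncertain, and a change larger than the scatter in either direction is possible. On balance, compound 4 is expected to show 2500 nM in this assay, with a broad range from 300 nM to 20000 nM.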

Compound 4, half-maximal inhibitory concentration: 39.4 nM
For compound 4 the middle estimate is 63-fold (1.80 log units) above the measured one; measured number below the stated range.
By their numbers in this assay, from the lowest: compound 4; then compounds 3 and 1 (each within the scatter of the next).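

In this assay, within the data shown here, compound 4 gives 39.4 nM while compound 2 has no number, so no step between them can be read. No data shown explain this result. The compounds shown leave open how 2-fluorophenyl and 4-methoxyphenyl compare numerically on this scale.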